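The source may report more compounds than this note shows. Statements on the series, on what has been measured and on what is new or still open speak of the compounds shown alone.

Two compounds of this series have been run in a functional assay on 786-0 cells (Homo sapiens) for inhibition, read by sulforhodamine B assay, with a stated time of 48 h (on this read-out higher numbers stand for weaker inhibition of growth and lower numbers for stronger inhibition of growth), and both share the same core, differing only in the group attached to the far end of the thiosemicarbazone. Compound 1 `CC1=CC[C@H](C(C)(C)NC(=S)N/N=C/c2cccs2)CC1` carries a thiophene ring there, and in this assay compound 1 gives 26700 nM. Compound 2 `CC1=CC[C@H](C(C)(C)NC(=S)N/N=C(\C)c2ccccc2)CC1` carries a phenyl ring with a methyl group on the linking carbon. For compound 2 this assay reports only a limit, > 100000 nM, and not a number, so compound 2 stands at the limit of > 100000 nM in this assay, at which 1 of the 2 values shown sits. Compound 3 `COc1ccc(/C(C)=N/NC(=S)NC(C)(C)[C@H]2CC=C(C)CC2)cc1` is compound 2 with one addition: methoxy in place of hydrogen on an aromatic carbon, a methoxy in place of hydrogen on an aromatic carbon, para to a large group. Going by the values given here, no comparable step has been measured, so the size of the change in this assay cannot be read from any neighbouring pair. Since compound 2 sits at the limit, the expectation for compound 3 is that the step of an at least 1.1-fold lower number from compound 2 to compound 3 (0.04 log units; that floor lies within the scatter) is small or none beyond the scatter. Compound 3 is therefore estimated at 90000 nM, with a range from 30000 nM to 300000 nM.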

Compound 3, concentration for total growth inhibition: > 100000 nM
Compound 3 was reported as a limit; the forecaster's own chance of this, stated with the estimate: 60%; middle value at least 1.1-fold (0.04 log units) from the limit.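

Compound 2 and compound 3 both stand at a limit in this assay and not at a number, so no step can be read from compound 2 to compound 3: the limit of > 100000 nM in this assay, at which 2 of the 3 values shown sit.

The compounds shown leave open whether a methoxy in place of hydrogen on an aromatic carbon changes growth inhibition at all, and in which direction.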